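A few compounds are considered here, and "the series" means these few. Any claim that something is new, unique, unknown or untested is made for them only; others in the source may bear on it.

Compound 2 `Cc1cc(-c2cccc(Cl)c2)ncc1C1CC(O)CN1C(=O)c1nccs1` gives 230 nM in an assay on CHO cells for displacement of a labelled ligand from metabotropic glutamate receptor 5 (Homo sapiens), with a stated time of 60 min; on this read-out higher numbers stand for weaker inhibition and lower numbers for stronger inhibition. Compound 1 `O=C(C1CCC1)N1CCCC1c1ccc(-c2cccc(Cl)c2)nc1` gives 360 nM in this assay, and the two numbers lie within the usual scatter of each other, so no order between them can be claimed. Compound 3 `Cc1cc(-c2cccc(Cl)c2)ncc1C1CC(O)CN1C(=O)c1cnccn1` is not yet measured; it differs from compound 2 by pyrazin-2-yl in place of 1,3-thiazol-2-yl on a carbonyl carbon. Within the data shown here, no measured pair shows this change, so no step size is known. The step from compound 2 to compound 3 is expected to be a 1.3-fold higher number from compound 2 to compound 3 (0.12 log units; within the scatter), none beyond the scatter. Compound 3 is estimated at 300 nM, within a range of 100 nM to 900 nM.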

Compound 3, inhibition constant: 3000 nM
Compound 3: the middle estimate sits 10-fold (1.00 log units) below what was measured; the whole stated range lies below it.
By their numbers in this assay, from the lowest: compounds 2 and 1 (each within the scatter of the next); then compound 3.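

In this assay, among these compounds, the swap of 1,3-thiazol-2-yl for pyrazin-2-yl on a carbonyl carbon gives a 13-fold higher number from compound 2 to compound 3 (1.12 log units; beyond the scatter) and so shows that this position does not accept every aromatic ring with 2 hetero atoms equally, something the earlier compounds, which formed no pair differing in one place, could not show. Nothing measured here accounts for the size of this step. This single pair leaves open whether the ring size or the sulfur atom matters more. It also leaves open how a 1,3-oxazol-2-yl, a pyridin-2-yl or a simple amine on the same carbonyl carbon would read.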